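Swapping Nitro for Chloro on a Cytotoxicity Read-out

The compounds below may be only part of what the source reports. "The series", "measured", "known", "first", "only" and "open" are said of these compounds alone.

Measured so far:
Compound 1 `CCOC(=O)c1sc(N/N=C/c2c(-c3ccc([N+](=O)[O-])cc3)[nH]c3ccccc23)nc1C`: 23500 nM
Compound 2 `CCC1S/C(=N\N=C\c2c(-c3ccc([N+](=O)[O-])cc3)[nH]c3ccccc23)NC1=O`: 25200 nM
Compound 3 `CCC1S/C(=N\N=C\c2c(-c3ccc(Cl)cc3)[nH]c3ccccc23)NC1=O`: 8800 nM

All three were tested in an ADME assay on MRC5 cells (Homo sapiens) for cytotoxicity, read by fluorescence, with a stated time of 24 h; a higher number here means a weaker inhibitor, a lower number a stronger inhibitor. Compound 2 and compound 3 share a core and differ in one place, (chloro in place of nitro on an aromatic carbon); that change gave a 2.9-fold lower number from compound 2 to compound 3 (0.46 log units; beyond the scatter). Compound 1 carries a different core from compound 2, and the difference between the two cores is not broken down here; their numbers in this assay sit within the scatter of each other.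

Compound 4 `CCOC(=O)c1sc(N/N=C/c2c(-c3ccc(Cl)cc3)[nH]c3ccccc23)nc1C` has not yet been measured. It stands to compound 1 as compound 3 stands to compound 2: the same change, (chloro in place of nitro on an aromatic carbon), at the same place. Within the data shown here, the one measured example of this change is a 2.9-fold lower number from compound 2 to compound 3 (0.46 log units; beyond the scatter). The expectation for compound 4 therefore rests on that example, and a step of similar size is expected, a 2.8-fold lower number from compound 1 to compound 4 (0.44 log units; beyond the scatter). Because the measured step rests on a single pair, the range is kept wide. Compound 4 is expected to give about 8500 nM, between 4000 nM and 20000 nM, in this assay.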

Compound 4, half-maximal inhibitory concentration: 25200 nM
For compound 4 the middle estimate is 3.0-fold (0.47 log units) below the measured one, outside the stated range (above it).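

Carrying this change from one core to another is not safe in this series, at least in this assay. On the core of compound 1, putting chloro in place of nitro gave a 1.1-fold higher number from compound 1 to compound 4 (0.03 log units; within the scatter), so the drop seen on the other core did not appear here. The two results truly differ, as the comparison of the same change on both cores shows: the same change on two cores in this assay, a 2.9-fold lower number (0.46 log units; beyond the scatter) from compound 2 to compound 3 and a 1.1-fold higher number (0.03 log units; within the scatter) from compound 1 to compound 4, 3.1-fold (0.49 log units) apart, beyond the scatter of two such steps. Among these compounds, this shows that the effect of the change depends on the core it sits on, but with only two pairs it does not show which part of the core matters, why the results differ, or which result would be more typical of other cores.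

The compounds shown carry only nitro and chloro at this place, so it remains open how a fluoro group or an amine there would behave on either core. From the compounds shown here alone, it also remains open whether a third core would follow compound 3 or compound 4 in its response to the same change.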